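Methoxy count on the pyrazole aryl and cytotoxicity

A few compounds are considered here, and "the series" means these few. Any claim that something is new, unique, unknown or untested is made for them only; others in the source may bear on it.

Measured so far:
compound 1 `COc1ccc(-c2cc(/C=C/C(=O)c3ccc(N)cc3)[nH]n2)cc1` — -83%
compound 2 `COc1cc(-c2cc(/C=C/C(=O)c3ccc(N)cc3)[nH]n2)cc(OC)c1OC` — -39%
compound 3 `COc1ccc(C(=O)/C=C/c2cc(-c3cc(OC)c(OC)c(OC)c3)n[nH]2)cc1OC` — -95%

In a functional assay on PC-3 cells (Homo sapiens) for cytotoxicity, read by sulforhodamine B assay, with a stated time of 48 h, tested at 100 uM (a lower number here means a stronger effect, a higher number a weaker effect of the compound at the concentration tested), compound 2 stands highest of the three numbers; compound 1 gives a number lower by a margin beyond the scatter, and compound 3 lies furthest from it. Within the data shown here, the only single-place step is a number 56 percentage points lower from compound 2 to compound 3 (beyond the scatter), which changes the aryl on the carbonyl carbon and so does not touch the position altered here. Compound 4 `COc1ccc(-c2cc(/C=C/C(=O)c3ccc(N)cc3)[nH]n2)cc1OC` differs from compound 2 by hydrogen in place of methoxy on an aromatic carbon. Among the measured compounds shown here, no measured step bears directly on this change; the values of compound 1 and compound 2 show that the compound with fewer methoxy groups on the pyrazole-attached aryl gave the lower number in this assay, but those two differ in more than one place, so that is only a hint. On that hint compound 4 is expected to fall between compound 2 and compound 1, a step of a number 26 percentage points lower from compound 2 to compound 4 (beyond the scatter) downward. For compound 4 the estimate in this assay is -65%, with a range from -90% to -35%.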

Compound 4, a percentage reported as activity, at one concentration (the size of the read-out at that concentration, not a potency): -48%
Compound 4: the middle estimate sits 17 percentage points below what was measured; low and high end bracket the measured number.
By their numbers in this assay, from the lowest: compound 3; then compound 1; then compounds 4 and 2 (each within the scatter of the next).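

In this assay the new step is a number 9 percentage points lower from compound 2 to compound 4 (within the scatter), so hydrogen and methoxy at this aromatic carbon cannot be told apart on the 4-aminophenyl series. The other step, a number 35 percentage points higher from compound 1 to compound 4 (beyond the scatter), is the one that counts, and it involves a different carbon of the same aryl. The earlier gap between compound 1 and compound 2 therefore does not follow the methoxy count evenly: one methoxy change accounts for a large shift and the other for none that can be read, so compound 2 and compound 4 go against any simple trend with count.

Open, going by these compounds, is whether hydroxy or ethoxy at this carbon would read like methoxy or hydrogen, and whether the same pair of steps holds with the 3,4-dimethoxyphenyl on the carbonyl carbon of compound 3. No data on hand explain either step.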